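A few compounds are considered here, and "the series" means these few. Any claim that something is new, unique, unknown or untested is made for them only; others in the source may bear on it.

Measured compounds in a functional assay on A549 cells (Homo sapiens) for cytotoxicity, read by MTT assay, with a stated time of 72 h; a higher number here means a weaker inhibitor, a lower number a stronger inhibitor:
- compound 1 `Cc1ccc(-c2ccnc(C(=O)Nc3ccc(Oc4ccnc5[nH]ccc45)cc3)n2)cc1`, 2380 nM
- compound 2 `O=C(Nc1ccc(Oc2ccnc3[nH]ccc23)cc1)c1cc(-c2ccc(Cl)cc2)ncn1`, 6530 nM
- compound 3 `Cc1ccc(-c2ccnc(C(=O)Nc3ccc(Oc4ccnc5[nH]ccc45)c(F)c3)n2)cc1`, 1150 nM

Compound 3 holds the lowest of the three numbers in this assay. For the measured compounds named here, its nearest neighbour is compound 1, separated by the one-place step a 2.1-fold lower number from compound 1 to compound 3 (0.32 log units; beyond the scatter); compound 2 lies furthest away, with a clearly higher number than compound 3, though no single-change step links those two.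

Compound 4 `O=C(Nc1ccc(Oc2ccnc3[nH]ccc23)c(F)c1)c1nccc(-c2ccc(Cl)cc2)n1` is the next member. It differs from compound 3 only in chloro in place of methyl on an aromatic carbon, on the ring that carries the pendant aryl group of the shared core.

Going by the values given here, no measured single-change step covers a methyl-to-chloro exchange; the only step in hand, a 2.1-fold lower number from compound 1 to compound 3 (0.32 log units; beyond the scatter), concerns the fluoro and does not bear directly on this change. Among the compounds with values here, compounds 1 and 2 do carry methyl and chloro at the same place, but they also differ in the core, so their two values show only that the chloro-bearing compound 2 sits at a higher number than the methyl-bearing compound 1 without isolating the cause. On that thin basis a modest rise is expected, a 2.2-fold higher number from compound 3 to compound 4 (0.34 log units; beyond the scatter), with wide uncertainty. Compound 4 is estimated at 2500 nM, within a range of 900 nM to 7000 nM.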

Compound 4, half-maximal inhibitory concentration: 8940 nM
The estimate for compound 4 lay 3.6-fold (0.55 log units) below the measured number; measured number outside the range, above it.
By their numbers in this assay, from the lowest: compound 3; then compound 1; then compounds 2 and 4 (each within the scatter of the next).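

In this assay, for the compounds shown here, the step of a 7.8-fold higher number from compound 3 to compound 4 (0.89 log units; beyond the scatter) gives the first single-change reading at the pendant aryl group, where the change from 4-methylphenyl to 4-chlorophenyl lies beyond the scatter. The position is therefore sensitive to the identity of this one substituent, para to a large group, even though methyl and chloro each count one heavy atom and neither adds a hydrogen-bond donor or acceptor. Going by these compounds alone, in size the step also exceeds the fluoro step a 2.1-fold lower number from compound 1 to compound 3 (0.32 log units; beyond the scatter), the only other single-change step, so on these compounds the substituent on the pendant aryl group moves the number further than the fluoro does, and no measurement at hand explains the change.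

The compounds shown leave open whether the methyl-to-chloro step would have the same size in a compound lacking the fluoro, as no such pair is available here. They also leave open how the series would read with an amine, a methoxy group or a carboxylic acid at this same place on the aryl ring, so a trend across substituents cannot yet be drawn from two groups.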